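A few compounds are considered here, and "the series" means these few. Any claim that something is new, unique, unknown or untested is made for them only; others in the source may bear on it.

Working notes on the series. Compound 1 `CCCN(CCC)C1=CC(=O)c2nc3n(c2C1=O)[C@H]1OC[C@@H](O)[C@H]1OC3` and compound 3 `CCCN(CCC)C1=CC(=O)c2c(nc3n2[C@H]2OC[C@@H](O)[C@H]2OC3)C1=O` are built from the same atoms joined differently; the difference between the two cores is not broken down here. In a functional assay on HeLa cells (Homo sapiens) for inhibition, read by sulforhodamine B assay (a lower number here means a stronger inhibitor, a higher number a weaker inhibitor), compound 1 reaches only the limit of > 16000 nM. Compound 3 likewise gives only the limit of > 16000 nM in this assay. Compound 2 `O=C1C=C(Nc2cccc(Cl)c2)C(=O)c2c1nc1n2[C@H]2OC[C@@H](O)[C@H]2OC1` carries the change (3-chlorophenyl)amino in place of dipropylamino on a double-bonded ring carbon on the core of compound 1, and in this assay compound 2 gives 6040 nM. The step of an at least 2.6-fold lower number from compound 1 to compound 2 (0.42 log units; beyond the scatter) is stated as a bound because of the limit of > 16000 nM in this assay, at which 2 of the 3 values shown sit. Compound 4 `O=C1C(Nc2cccc(Cl)c2)=CC(=O)c2c1nc1n2[C@H]2OC[C@@H](O)[C@H]2OC1` is the unmeasured partner on the core of compound 3, carrying the same change, ((3-chlorophenyl)amino in place of dipropylamino on a double-bonded ring carbon). The expectation for compound 4 rests on compound 2 with 6040 nM and on the step of an at least 2.6-fold lower number from compound 1 to compound 2 (0.42 log units; beyond the scatter). An expected step of an at least 2.4-fold lower number from compound 3 to compound 4 (0.39 log units; beyond the scatter) in this assay is therefore estimated, of the same kind as the measured one, with the reservation that the starting point sits at a limit. Compound 4 is expected at 6500 nM, within an estimated range from 2500 nM to 16000 nM.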

Compound 4, half-maximal inhibitory concentration: 7970 nM
Compound 4: the middle estimate sits 1.2-fold (0.09 log units) below what was measured, within the range that was stated.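

In this assay, (3-chlorophenyl)amino in place of dipropylamino on a double-bonded ring carbon gives an at least 2.0-fold lower number from compound 3 to compound 4 (0.30 log units; that floor lies within the scatter). This agrees with the earlier step in direction, so the change carries over to the second core as far as these two pairs show, but it does not establish that the change does the same amount on both cores: the same change on two cores in this assay, an at least 2.6-fold lower number (0.42 log units; beyond the scatter) from compound 1 to compound 2 and an at least 2.0-fold lower number (0.30 log units; that floor lies within the scatter) from compound 3 to compound 4; the limit leaves it open whether they differ. Both steps are bounds rather than measured sizes, so neither gives the true extent of the change on its core, because both starting compounds sit at a limit of the assay: the limit of > 16000 nM in this assay, at which 2 of the 4 values shown sit.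

The compounds shown leave open which part of the change goes with the lower numbers: the aromatic ring, the chlorine or the added hydrogen-bond donor. A plain phenylamino group and a propylamino group on the same ring carbon of both cores would begin to separate these parts.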